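Adding chloro to the core of compound 3

This account rests on a few compounds, and the source may have more. Where it says the series, first, only, none or still open, it means among the compounds named here.

Measured compounds:
`O=C(c1nc2cc(Cl)ccc2s1)N1CCN(c2ccccc2)CC1` compound 1, 41.2%
`O=C(c1nc2cc(Cl)ccc2s1)N1CCN(c2cnccn2)CC1` compound 2, 54.9%
`COc1ccccc1N1CCN(C(=O)c2nc3ccccc3s2)CC1` compound 3, 53.4%

In an ADME assay on RAW264.7 cells (Mus musculus) for cytotoxicity, read by MTT assay, with a stated time of 72 h, tested at 50 ug/mL (a lower number here means less inhibition, a higher number more inhibition at the concentration tested (going by the name of the read-out)), compound 3 sits within the scatter of compound 2 and clearly above compound 1. Compound 4 `COc1ccccc1N1CCN(C(=O)c2nc3cc(Cl)ccc3s2)CC1` differs from compound 3 by chloro in place of hydrogen on an aromatic carbon. Within the data shown here, no measured pair shows this change: compound 1 and compound 2 both carry the chloro, compound 3 does not, and the only measured step, a number 13.7 percentage points higher from compound 1 to compound 2 (beyond the scatter), concerns a different part of the molecule. Among the measured compounds shown here, with no step to lean on, no change beyond the scatter is expected, so compound 4 is estimated at 53%, between 40% and 66%, a step of a number 0.4 percentage points lower from compound 3 to compound 4 (within the scatter).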

Compound 4, a percentage reported as inhibition, at one concentration (the size of the read-out at that concentration, not a potency): 63.4%
The estimate for compound 4 lay 10.4 percentage points below the measured number, and the stated range covers the measured number.
By their numbers in this assay, from the lowest: compound 1; then compounds 3, 2 and 4 (each within the scatter of the next).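

In this assay, chloro in place of hydrogen on the core gives a number 10 percentage points higher from compound 3 to compound 4 (within the scatter), so this first test of the position stays inside the usual scatter. With the chloro present, methoxy in place of hydrogen gives a number 22.2 percentage points higher from compound 1 to compound 4 (beyond the scatter), while 2-methoxyphenyl in place of pyrazin-2-yl gives a number 8.5 percentage points higher from compound 2 to compound 4 (within the scatter), so only the first of these two changes clearly separates its pair. No measurement here explains these steps. As far as these compounds go, whether bromo, methyl or an amine on the same aromatic carbon would behave like chloro stays open.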